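The compounds below may be only part of what the source reports. "The series", "measured", "known", "first", "only" and "open" are said of these compounds alone.

Measured so far:
- compound 1, `COc1ccc(CNc2nc(N)nc(-c3ccccc3CO)n2)cc1`: 3.34
- compound 2, `CCOc1ccc(CNc2nc(N)nc(-c3ccccc3CO)n2)cc1`: 4.77

In a functional assay on cells for positive allosteric modulation of G-protein coupled receptor 68 (Homo sapiens), read by a luciferase reporter and cAMP accumulation, with a stated time of 30 min, at pH 6.8 and pH 8.3, in the presence of a further agent that is not named here (a higher number here means a more potent compound, by a factor of ten per unit of this negative logarithm, a lower number a less potent compound), compound 2 gives 4.77, the higher of the two numbers measured; its nearest neighbour, compound 1, gives 3.34. Within the data shown here, the only measured step, a number 1.43 log units higher from compound 1 to compound 2 (beyond the scatter), is large and well beyond the scatter, so lengthening the chain on the oxygen on the aromatic ring paid off once. Compound 3, `Nc1nc(NCc2ccc(Oc3ccccc3)cc2)nc(-c2ccccc2CO)n1`, takes this further: phenyl in place of ethyl on an oxygen on an aromatic ring. The same difference, cut one bond further out, reads ethoxy to phenoxy. Among the measured compounds shown here, the single step bears on this change only loosely, since an aromatic ring is not simply a longer chain; still, the one direction seen is upward, and a modest further gain in this assay is expected rather than a loss, with a wide range to reflect the thin evidence. Compound 3 is therefore estimated at 5.2, between 4.2 and 6.2. This expectation corresponds to a number 0.43 log units higher from compound 2 to compound 3 (beyond the scatter).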

Compound 3, negative logarithm of the antagonist equilibrium constant: 5.19
Compound 3: middle estimate off by 0.01 log units, on the high side; low and high end bracket the measured number.
By their numbers in this assay, from the lowest: compound 1; then compound 2; then compound 3.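

In this assay the oxygen on the aromatic ring now carries a ring instead of a chain, and the result is a number 0.42 log units higher from compound 2 to compound 3 (beyond the scatter), so this position accepts phenyl as well as ethyl without a loss. Measured against the methyl group, phenyl gives a number 1.85 log units higher from compound 1 to compound 3 (beyond the scatter) and most of that rise was already present with ethyl, since the step from ethyl to phenyl is only modest. Nothing measured here explains either rise.

The compounds shown leave open whether the gain depends on the aromatic ring itself or would also appear with a longer chain such as propyl or butyl on the same oxygen. As far as these compounds go, it also remains open how a benzyl group there, or a fluorine or an amine on the new phenyl ring, would change the number.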